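Trimming the Pyridyl Arm to a Methyl

A few compounds are considered here, and "the series" means these few. Any claim that something is new, unique, unknown or untested is made for them only; others in the source may bear on it.

Compound 1 `c1ccc2c(-c3nnc(-c4ccncc4)o3)c[nH]c2c1` is the only one of the three measured compounds with a number: in a functional assay on PC-3 cells (Homo sapiens) for cytotoxicity, read by MTT assay (on this read-out higher numbers stand for weaker inhibition and lower numbers for stronger inhibition), compound 1 gives 4100 nM. Compound 2 `COc1ccc(-c2nnc(-c3c[nH]c4ccccc34)o2)cc1OC` reaches only a limit, > 1000000 nM. Compound 3 `COc1cc(-c2nnc(-c3c[nH]c4ccccc34)o2)ccc1O` likewise reaches only a limit, > 1000000 nM. The step from compound 2 to compound 3, a step that the two limits leave unreadable from compound 2 to compound 3, is therefore unreadable in size. Compound 4 `Cc1nnc(-c2c[nH]c3ccccc23)o1` differs from compound 1 by methyl in place of pyridin-4-yl on an aromatic carbon. For the measured compounds named here, no measured step concerns this change directly; what compounds 2 and 3 show is that other groups in place of the pyridin-4-yl sit at the limit of > 1000000 nM in this assay, at which 2 of the 3 values shown sit. Compound 4 is therefore expected to lose potency, with an estimated step of a 9.8-fold higher number from compound 1 to compound 4 (0.99 log units; beyond the scatter). Compound 4 is estimated at 40000 nM in this assay, within 4000 nM to 400000 nM.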

Compound 4, half-maximal inhibitory concentration: > 1000000 nM
Compound 4: no number, only a limit (the forecaster's own chance of this, stated with the estimate: 35%); middle value at least 25-fold (1.39 log units) away from the limit.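

Methyl in place of pyridin-4-yl on this aromatic carbon brings an at least 240-fold higher number from compound 1 to compound 4 (2.38 log units; beyond the scatter) in this assay. For the compounds shown here, this is the first step at this position that can be read, and it shows that a group without a ring does not keep the activity of compound 1. Of the groups shown here, only pyridin-4-yl gives a number, and the others stop at one limit: the limit of > 1000000 nM in this assay, at which 3 of the 4 values shown sit.

On these data alone, whether the ring nitrogen of the pyridin-4-yl is needed stays open, and an unsubstituted phenyl or a pyridin-3-yl at this position would address that. As far as these compounds go, how an amine or a longer alkyl chain would read here also remains unknown.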